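The source may hold more compounds than are shown below. What is called first, only, known or untested is meant among the compounds shown, and "the series" means these compounds.

Measured compounds:
- compound 1 `COc1cc2c(cc1OC)C(=O)/C(=C/c1cccc(O)c1)CO2` — in an assay on isolated protein for inhibition of Amine oxidase [flavin-containing] B (Homo sapiens), read by fluorescence, with a stated time of 30 min (on this read-out higher numbers stand for weaker inhibition and lower numbers for stronger inhibition), compound 1 gives 190 nM
- compound 2 `COc1cc2c(cc1OC)C(=O)/C(=C/c1ccc(CN3CCCC3)c(O)c1)CO2` — compound 2 gives 722 nM
- compound 3 `COc1cc2c(cc1OC)C(=O)/C(=C/c1ccc(CN3CCCCC3)c(O)c1)CO2` — compound 3 gives 1740 nM

Compound 3 gives the highest number of the three, so in this assay it is the weakest inhibitor shown. Compound 4 `CCN(Cc1ccccc1)Cc1ccc(/C=C2\COc3cc(OC)c(OC)cc3C2=O)cc1O` is not yet measured. It differs from compound 3 in one place: benzyl(ethyl)amino in place of piperidin-1-yl on a saturated chain carbon bound to an aromatic carbon.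

For the measured compounds named here, three measured steps bear on this change. Adding a (pyrrolidin-1-yl)methyl group gave a 3.8-fold higher number from compound 1 to compound 2 (0.58 log units; beyond the scatter), adding a (piperidin-1-yl)methyl group gave a 9.2-fold higher number from compound 1 to compound 3 (0.96 log units; beyond the scatter), and swapping the smaller cyclic amine for the larger one gave a 2.4-fold higher number from compound 2 to compound 3 (0.38 log units; beyond the scatter). Each time the amine part on that saturated chain carbon grew, the number rose. Compound 4 carries the largest amine of the set, so a further rise beyond the scatter is expected, of modest size, as a 2.0-fold higher number from compound 3 to compound 4 (0.30 log units; within the scatter). Compound 4 is therefore estimated at 3500 nM, with a range from 1200 nM to 10000 nM.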

Compound 4, half-maximal inhibitory concentration: 1720 nM
The estimate for compound 4 lay 2.0-fold (0.31 log units) above the measured number; the range from low to high includes it.
By their numbers in this assay, from the lowest: compound 1; then compound 2; then compounds 4 and 3 (each within the scatter of the next).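

In this assay, enlarging the group on a saturated chain carbon bound to an aromatic carbon from piperidin-1-yl to benzyl(ethyl)amino, which has 10 heavy atoms rather than 6 and an aromatic ring of carbon only, gives a 1.0-fold lower number from compound 3 to compound 4 (0.01 log units; within the scatter), a step within the scatter. Compound 4 therefore goes against the earlier pattern of a higher number with each larger amine, even though the number remains raised relative to the other two, with a 2.4-fold higher number from compound 2 to compound 4 (0.38 log units; beyond the scatter) and a 9.1-fold higher number from compound 1 to compound 4 (0.96 log units; beyond the scatter). No evidence is available to explain why the larger group brings no further rise.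

It remains open whether a smaller open-chain amine such as dimethylamino would sit nearer to compound 1 than the groups shown. From the compounds shown here alone, the effect of a ring holding a second hetero atom, such as morpholin-4-yl, also remains open.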